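A Methylated Tetrazole in Place of 1-Methoxyethyl

This account rests on a few compounds, and the source may have more. Where it says the series, first, only, none or still open, it means among the compounds named here.

In a functional assay (blood) for inhibition, with Homo sapiens as the target (a higher number here means a weaker inhibitor, a lower number a stronger inhibitor), compound 1 `CC(O)c1cc(-c2ccccc2)c2ccc(OCc3cccc(C4(O)CCOCC4)c3)cc2c1` gives 675 nM. Compound 2 `COC(C)c1cc(-c2ccccc2)c2ccc(OCc3cccc(C4(O)CCOCC4)c3)cc2c1`, its methyl ether, has no number of its own and is reported only as the limit > 1000 nM. Compound 3 `OC1(c2cccc(COc3ccc4c(-c5ccccc5)cc(-c5nn[nH]n5)cc4c3)c2)CCOCC1`, which carries 2H-tetrazol-5-yl, is likewise reported only as the limit > 3000 nM. As far as these compounds go, compound 2 therefore stands as one of two limits among the three values available, and its true position is unknown.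

Compound 4 `Cn1nnc(-c2cc(-c3ccccc3)c3ccc(OCc4cccc(C5(O)CCOCC5)c4)cc3c2)n1` differs from compound 2 by one change, 2-methyl-2H-tetrazol-5-yl in place of 1-methoxyethyl on an aromatic carbon. Among the compounds with values here, three measured steps bear on this change. Methylating the oxygen gives an at least 1.4-fold higher number from compound 1 to compound 2 (0.17 log units; that floor lies within the scatter), a floor that lies within the scatter. Introducing the unmethylated tetrazole gives an at least 4.4-fold higher number from compound 1 to compound 3 (0.64 log units; beyond the scatter), which lies beyond it and is at least modest. The direct comparison is a step that the two limits leave unreadable from compound 2 to compound 3, so it supplies no size.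

With compound 3 as the closest guide, through an at least 4.4-fold higher number from compound 1 to compound 3 (0.64 log units; beyond the scatter), compound 4 is expected to remain on the high-number side of compound 1, and no clear step from compound 2 is expected. The expected step is a step that the limit leaves unreadable from compound 2 to compound 4. Compound 4 is estimated at 1200 nM, within an expected range of 400 nM to 3500 nM.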

Compound 4, half-maximal inhibitory concentration: 310 nM
Compound 4: the middle estimate sits 3.9-fold (0.59 log units) above what was measured, outside the stated range (below it).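

In this assay, within the data shown here, a tetrazole at this aromatic carbon need not cost activity: 2-methyl-2H-tetrazol-5-yl in place of 1-hydroxyethyl gives a 2.2-fold lower number from compound 1 to compound 4 (0.34 log units; beyond the scatter), whereas no earlier step at this position had lowered the number. The methyl separates the two tetrazoles, as methyl in place of hydrogen on the aromatic nitrogen gives an at least 9.6-fold lower number from compound 3 to compound 4 (0.98 log units; beyond the scatter). 2-Methyl-2H-tetrazol-5-yl in place of 1-methoxyethyl gives an at least 3.2-fold lower number from compound 2 to compound 4 (0.50 log units; beyond the scatter), and this step and the one before it are only floors, with compound 2 and compound 3 each reported only as a limit.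

The values shown give no reason for these steps, and they cannot tell whether the gain depends on the methyl sitting at that particular ring nitrogen or would hold for any small group there. The compounds shown leave open how the isomeric 1-methyl-1H-tetrazol-5-yl or a longer chain such as 2-ethyl-2H-tetrazol-5-yl would compare with compound 4 at this aromatic carbon.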